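Fluoro Added on the Sulfone Ring: Efficacy Working Notes

The source may hold more compounds than are shown below. What is called first, only, known or untested is meant among the compounds shown, and "the series" means these compounds.

Compound 1 `CS(=O)(=O)c1cccc(C#Cc2cc(Cl)ccc2OCC(=O)O)c1` stands lowest of the two numbers recorded in a functional assay on CHO cells for agonist activity at prostaglandin D2 receptor 2 (Homo sapiens) (a higher number here means a larger maximal response, a lower number a smaller maximal response), giving 10%. Among the compounds with values here, compound 2 `CCCS(=O)(=O)c1cccc(C#Cc2cc(C#N)ccc2OCC(=O)O)c1` is nearest and gives 30% in this assay, a gap beyond the usual scatter; the two differ in more than one place, so no single step connects them. Compound 3 `CS(=O)(=O)c1ccc(F)c(C#Cc2cc(Cl)ccc2OCC(=O)O)c1` arises from compound 1 by fluoro in place of hydrogen on an aromatic carbon. Within the data shown here, no measured pair shows this change in this assay, so the expectation rests on compound 1 alone, at 10%, and a small step is expected, within the scatter or barely beyond, direction uncertain. Compound 3 is estimated at 15%, with a range from 5% to 30%. The expected step of a number 5 percentage points higher from compound 1 to compound 3 (within the scatter) is small.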

Compound 3, largest response reached (Emax), in percent of the reference or control that the assay uses: 10%
Estimate against measurement, compound 3: 5 percentage points above; measured number inside the range.
By their numbers in this assay, from the lowest: compounds 1 and 3 (each within the scatter of the next); then compound 2.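

In this assay fluoro in place of hydrogen on an aromatic carbon, para to a methylsulfonyl group and ortho to a large group, shows no change at the digits printed from compound 1 to compound 3 (within the scatter) and gives the series its first single-place step. At this position, the added fluoro leaves the maximal response unchanged in this one pair. No measurement bearing on the reason is available.

Going by these compounds, whether an amine or a longer chain at this position would alter the maximal response stays open. Compound 2 differs from compound 1 in more than one place, so its higher number cannot be assigned to any single change.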